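Cyclohexyl for 4-Bromophenyl on an Indole Ester Core

The source may hold more compounds than are shown below. What is called first, only, known or untested is meant among the compounds shown, and "the series" means these compounds.

Measured compounds:
compound 1 `COC(=O)c1[nH]c2cc(OC)ccc2c1-c1ccc(Br)cc1` gives 200 nM
compound 2 `COC(=O)c1[nH]c2cc(OC)ccc2c1C(C)C` gives 81500 nM

In a functional assay on RS4-11 cells (Homo sapiens) for antiproliferative activity, read by MTT assay, with a stated time of 48 h (on this read-out lower numbers stand for an effect already at smaller amounts and higher numbers for an effect only at larger amounts of compound), compound 1 stands at the lower of the two numbers recorded, and its nearest neighbour is compound 2, reached by a 410-fold higher number from compound 1 to compound 2 (2.61 log units; beyond the scatter). Compound 3 `COC(=O)c1[nH]c2cc(OC)ccc2c1C1CCCCC1` has not been measured; it differs from compound 1 by cyclohexyl in place of 4-bromophenyl on an aromatic carbon. Among the measured compounds shown here, the one measured step that bears on this change is the replacement of 4-bromophenyl by isopropyl, which was large: a 410-fold higher number from compound 1 to compound 2 (2.61 log units; beyond the scatter). Cyclohexyl, like isopropyl, is not aromatic, so a step in the same direction and beyond the scatter is expected, though perhaps not as far, given that a six-membered non-aromatic ring enters rather than a small chain. For compound 3 the expected step is a 50-fold higher number from compound 1 to compound 3 (1.70 log units; beyond the scatter), giving an estimated value of 10000 nM with a range from 2000 nM to 50000 nM.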

Compound 3, half-maximal effective concentration: > 100000 nM
Compound 3 gave a limit, no number (the forecaster's own chance of this, stated with the estimate: 5%); middle value at least 10-fold (1.00 log units) from the limit.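

In this assay compound 3 gives > 100000 nM, which is a limit of the assay and not a number: the limit of > 100000 nM in this assay, at which 1 of the 3 values shown sits.

Replacing the aromatic ring of 4-bromophenyl with the non-aromatic six-membered carbon ring of cyclohexyl gives an at least 500-fold higher number from compound 1 to compound 3 (2.69 log units; beyond the scatter), so a six-membered carbon ring on this aromatic carbon does not by itself keep the effect of compound 1. Cyclohexyl in place of isopropyl gives an at least 1.2-fold higher number from compound 2 to compound 3 (0.08 log units; that floor lies within the scatter), so compound 2 and compound 3 cannot be told apart here, and neither non-aromatic group comes close to 4-bromophenyl.

The compounds shown leave open whether the aromatic ring, the bromine on it, or both account for this gap, as cyclohexyl lacks both. Also open, as far as these compounds go, is how a plain phenyl group, or a phenyl ring carrying an amine or a carboxylic acid in place of the bromine, would behave at this position.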